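A few compounds are considered here, and "the series" means these few. Any claim that something is new, unique, unknown or untested is made for them only; others in the source may bear on it.

In a functional assay on MCF7 cells (Homo sapiens) for antiproliferative activity, read by MTT assay, with a stated time of 48 h (a higher number here means a weaker inhibitor, a lower number a stronger inhibitor), compound 2 `O=C1C=CC2(C=C1)OC(=O)C(c1cc3ccccc3o1)=C2c1ccccc1` gives 5800 nM, the lowest of the three numbers recorded. Compound 3 `N#Cc1ccc(C2=C(c3ccccc3)C3(C=CC(=O)C=C3)OC2=O)cc1` gives 19000 nM, and compound 1 `COc1ccc(OC(=O)C#Cc2ccccc2)cc1` gives 52600 nM. Compound 4 `O=C1C=CC2(C=C1)OC(=O)C(c1ccc(C(=O)O)cc1)=C2c1ccccc1` has not yet been measured; it differs from compound 2 by 4-carboxyphenyl in place of 1-benzofuran-2-yl on a double-bonded ring carbon. Among the measured compounds shown here, only one measured step bears on this change, because it replaced the same benzofuranyl group with a substituted phenyl ring: a 3.3-fold higher number from compound 2 to compound 3 (0.52 log units; beyond the scatter). On that basis a step of similar size and direction is expected for the carboxyphenyl analogue, namely a 2.6-fold higher number from compound 2 to compound 4 (0.41 log units; beyond the scatter). Compound 4 is therefore estimated to give 15000 nM in this assay, with a likely range from 6000 nM to 40000 nM.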

Compound 4, half-maximal inhibitory concentration: 5950 nM
Beside the measured number, compound 4's estimate is 2.5-fold (0.40 log units) above it; measured number below the stated range.
By their numbers in this assay, from the lowest: compounds 2 and 4 (each within the scatter of the next); then compound 3; then compound 1.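

In this assay, 4-carboxyphenyl in place of 1-benzofuran-2-yl on the double-bonded ring carbon gives a 1.0-fold higher number from compound 2 to compound 4 (0.01 log units; within the scatter) and so shows that this position can lose the benzofuran without a step beyond the scatter, which compound 3 alone did not show. Carboxy in place of cyano on the phenyl ring gives a 3.2-fold lower number from compound 3 to compound 4 (0.50 log units; beyond the scatter) and so shows that the earlier step depends on the group carried by that ring. No measured evidence accounts for either step. The compounds shown leave open whether an amine or a methyl ester in place of the carboxy group would keep the number of compound 4, and what an unsubstituted phenyl ring would give at this position.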